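Swapping the Side-Chain Amine in a Receptor Binder

This account rests on a few compounds, and the source may have more. Where it says the series, first, only, none or still open, it means among the compounds named here.

Measured compounds:
compound 1, `Cc1cc(C)c(N2CCCn3c2nc(C)c3C(=O)N(CC2CC2)CC2CC2)c(C)c1`: 3400 nM
compound 2, `CCN(Cc1c(C(F)(F)F)nc2n1CCCN2c1c(C)cc(C)cc1C)CC1CC1`: 31 nM

Both compounds were tested in an in vitro assay on IMR-32 cells for displacement of a labelled ligand from corticotropin-releasing factor receptor 1 (Homo sapiens); on this read-out higher numbers stand for weaker inhibition and lower numbers for stronger inhibition. Of the two numbers, compound 2 has the lowest; in this assay compound 1 gives a value that is beyond the usual scatter apart from it, so compound 2 is the stronger binder of the pair. The two compounds differ in more than one place, so nothing can be said about what any single change contributes.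

Compound 3, `Cc1cc(C)c(N2CCCn3c2nc(C(F)(F)F)c3CN2CCCN(C)CC2)c(C)c1`, has not yet been measured. It keeps the core, the trifluoromethyl group and the trimethylphenyl group of compound 2 and differs only in the amine carried on the side chain: 4-methyl-1,4-diazepan-1-yl in place of (cyclopropylmethyl)(ethyl)amino on a saturated chain carbon bound to an aromatic carbon. Among the compounds with values here, no measured pair in this set isolates such a swap, so its effect is unknown from the data. Given only the strong binding of compound 2 at 31 nM, a modest weakening is expected, a 6.5-fold higher number from compound 2 to compound 3 (0.81 log units; beyond the scatter), though a change within the scatter is also plausible. Compound 3 is estimated at 200 nM, with a likely range of 40 nM to 1500 nM.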

Compound 3, inhibition constant: > 5000 nM
Compound 3 ended at the assay's limit (the forecaster's own chance of this, stated with the estimate: 5%); middle value at least 25-fold (1.39 log units) away from the limit.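

In this assay, changing only the amine on the side chain, with the core, the trifluoromethyl group and the trimethylphenyl group kept, gives an at least 160-fold higher number from compound 2 to compound 3 (2.20 log units; beyond the scatter). Within the data shown here, this is the first comparison in the set that isolates a single change, and it shows that binding is highly sensitive to which amine sits on this saturated chain carbon bound to an aromatic carbon. Compound 3 carries a limit of the assay, not a number: the limit of > 5000 nM in this assay, at which 1 of the 3 values shown sits.

The swap alters several things at once: the open-chain amine with its three-membered carbon ring gives way to a seven-membered ring that holds two nitrogens, and the compounds shown cannot say which of these differences accounts for the large step. Going by these compounds, how a piperidine, whose ring holds only one nitrogen, or a plain diethylamino group would read on the same chain carbon remains open, and so does whether any amine at this place can improve on the value of compound 2, 31 nM.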